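Fluoro in place of methoxy: an estimate for compound 4

A few compounds are considered here, and "the series" means these few. Any claim that something is new, unique, unknown or untested is made for them only; others in the source may bear on it.

Compound 1, `Fc1ccc(-c2cn3ccnc3c(-c3ccc4ncn(C5CCCCC5)c4c3)n2)cc1`, gives 37.8% in a functional assay on UO-31 cells (Homo sapiens) for inhibition, read by sulforhodamine B assay, with a stated time of 48 h, tested at 10 uM; on this read-out lower numbers stand for less inhibition and higher numbers for more inhibition at the one concentration tested (going by the name of the read-out).
Compound 2, `Clc1ccc(-c2cn3ccnc3c(-c3ccc4ncn(C5CCCCC5)c4c3)n2)cc1`, gives 36.1%.
Compound 3, `COc1ccccc1-c1cn2ccnc2c(-c2ccc3ncn(C4CCCCC4)c3c2)n1`, gives 24%.

Compound 3 stands lowest of the three: its inhibition is a number 13.8 percentage points lower from compound 1 to compound 3 (beyond the scatter) and a number 12.1 percentage points lower from compound 2 to compound 3 (beyond the scatter), both beyond the scatter, while the two halogen compounds sit close together, as shown by a number 1.7 percentage points lower from compound 1 to compound 2 (within the scatter).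

Compound 4, `Fc1ccccc1-c1cn2ccnc2c(-c2ccc3ncn(C4CCCCC4)c3c2)n1`, has not yet been measured. It differs from compound 3 by a single change: fluoro in place of methoxy on an aromatic carbon. Going by the values given here, no measured step tests this exact swap. The two steps that lead to compound 3 move both the kind of group and where it sits on the ring, so they only hint that the 2-methoxyphenyl arrangement gives the lower number in this assay here, and they say nothing about a fluoro in the same place. The step from compound 3 to compound 4 in this assay is therefore expected to be small or modest, most likely upward, giving a number 6 percentage points higher from compound 3 to compound 4 (within the scatter). Compound 4 is estimated at 30%, within a range from 17% to 43%.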

Compound 4, a percentage reported as inhibition, at one concentration (the size of the read-out at that concentration, not a potency): 22.9%
The estimate for compound 4 lay 7.1 percentage points above the measured number; the range from low to high includes it.
By their numbers in this assay, from the lowest: compounds 4 and 3 (each within the scatter of the next); then compounds 2 and 1 (each within the scatter of the next).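

The swap of methoxy for fluoro, on an aromatic carbon ortho to a large group, removes one heavy atom and the one hydrogen-bond acceptor of the leaving group, yet in this assay it leaves the read-out almost unchanged, with a number 1.1 percentage points lower from compound 3 to compound 4 (within the scatter) as the whole effect. Compound 1 and compound 4 carry the same fluoro on the same kind of ring and differ only in where it sits, and a number 14.9 percentage points lower from compound 1 to compound 4 (beyond the scatter) is the first step that separates place from group: the place alone goes with a lower number among these compounds, and a number 13.2 percentage points lower from compound 2 to compound 4 (beyond the scatter) agrees, although that step also changes the halogen. Nothing shown explains why these numbers fall as they do.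

On these data alone, whether this place accepts anything at all remains open, since an amine or a carboxylic acid there, or a longer chain such as butoxy, could read quite differently from methoxy and fluoro. As far as these compounds go, it is also open whether a methoxy placed where the fluoro of compound 1 sits would match the halogen compounds.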